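The source may hold more compounds than are shown below. What is called first, only, known or untested is meant among the compounds shown, and "the series" means these compounds.

The series shares one core, varied only on the aromatic ring of the benzyl group. Compound 1 `C=CC1=C(C(=O)NCc2ccc(Cl)cc2)C(c2ccc(OC)cc2)OC1` carries chloro there; in a functional assay on QGY7701 cells (Homo sapiens) for cytotoxicity, read by MTT assay, with a stated time of 24 h (on this read-out lower numbers stand for stronger inhibition and higher numbers for weaker inhibition), compound 1 gives only a limit of the assay, > 100000 nM. Among the compounds with values here, compound 2 `C=CC1=C(C(=O)NCc2ccc(C)cc2)C(c2ccc(OC)cc2)OC1` carries methyl in place of chloro, and in this assay compound 2 gives 43100 nM, the only genuine number among the two values shown. The remaining value, that of compound 1, is the limit of > 100000 nM in this assay, at which 1 of the 2 values shown sits. Within the data shown here, the single measured step is an at least 2.3-fold lower number from compound 1 to compound 2 (0.36 log units; beyond the scatter). Compound 3 `C=CC1=C(C(=O)NCc2ccccc2)C(c2ccc(OC)cc2)OC1` differs from compound 2 by hydrogen in place of methyl on an aromatic carbon. Among the measured compounds shown here, no measured step covers hydrogen against methyl at this place; the one change recorded, chloro to methyl, favoured methyl, so for compound 3 the expected step is a 1.5-fold higher number from compound 2 to compound 3 (0.18 log units; within the scatter), a modest weakening at most and possibly within the scatter. Compound 3 is therefore estimated at 65000 nM, within a range from 25000 nM to 170000 nM.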

Compound 3, half-maximal inhibitory concentration: > 100000 nM
Compound 3: no number, only a limit (the forecaster's own chance of this, stated with the estimate: 30%); at least 1.5-fold (0.18 log units) between middle value and limit.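

Taking the methyl off the 4-methylbenzyl group to leave benzyl raises the number again: in this assay the change gives an at least 2.3-fold higher number from compound 2 to compound 3 (0.36 log units; beyond the scatter). Compound 3 gives only a limit of the assay, and this limit is now shared by two of the compounds: the limit of > 100000 nM in this assay, at which 2 of the 3 values shown sit. Among the compounds shown, methyl at this place, para to a large group, is thus the only group with a genuine number, against both chloro and hydrogen, while the step between chloro and hydrogen cannot be read.

The compounds shown leave open whether a longer chain such as ethyl, or an amine or a methoxy group, would also give a genuine number at this place. They also leave open whether an amine or a carboxylic acid elsewhere on the shared core would move the number.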